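The compounds below may be only part of what the source reports. "The series", "measured", "known", "first", "only" and "open" are said of these compounds alone.

Compound 1 `c1ccc(CNCC2CCN(CCCc3c[nH]c4ccc(-n5cnnc5)cc34)CC2)cc1`: 5.6 nM
Compound 2 `OC[C@H](NC1CCN(CCCc2c[nH]c3ccc(-n4ccnc4)cc23)CC1)c1ccccc1`: 0.8 nM
Compound 3 `c1ccc2c(c1)CCC2NC1CCN(CCCc2c[nH]c3ccc(-n4cnnc4)cc23)CC1`: 25 nM

In an assay on CHO cells for agonist activity at 5-hydroxytryptamine receptor 1D (Homo sapiens), read by GTPgammaS binding (a lower number here means that less compound is needed, a higher number that more compound is needed for the effect), compound 3 gives the highest of the three numbers, with compound 1 nearest and compound 2 furthest from it. Compound 4 `C[C@@H](NC1CCN(CCCc2c[nH]c3ccc(-n4cnnc4)cc23)CC1)c1ccccc1` differs from compound 3 by 1-phenylethyl in place of 2,3-dihydro-1H-inden-1-yl on an amine nitrogen. For the measured compounds named here, the one measured step that bears on this is a 4.5-fold higher number from compound 1 to compound 3 (0.65 log units; beyond the scatter), in which the (2,3-dihydro-1H-inden-1-yl)amino group raised the number relative to the (benzylamino)methyl group; compound 4 moves back toward an open-chain amine substituent. Compound 2 differs from compound 3 in more than one place, but compound 2 gives 0.8 nM in this assay, showing that an open-chain amine on this core can reach a low number. A lower number is therefore expected for compound 4, a step of a 6.3-fold lower number from compound 3 to compound 4 (0.80 log units; beyond the scatter). Compound 4 is estimated at 4 nM, with a range of 1 nM to 15 nM.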

Compound 4, half-maximal effective concentration: 13 nM
Beside the measured number, compound 4's estimate is 3.3-fold (0.51 log units) below it; the measured number falls inside the stated range.
By their numbers in this assay, from the lowest: compound 2; then compound 1; then compounds 4 and 3 (each within the scatter of the next).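

In this assay, 2,3-dihydro-1H-inden-1-yl and 1-phenylethyl on this amine nitrogen are not told apart, with a 1.9-fold lower number from compound 3 to compound 4 (0.28 log units; within the scatter), so the closed five-membered ring is not needed to hold the number at this level. The open-chain group does not recover the (benzylamino)methyl result either, with a 2.3-fold higher number from compound 1 to compound 4 (0.37 log units; beyond the scatter), and this step stays beyond the scatter. No measured evidence accounts for either step.

Going by these compounds, what a longer chain in place of the methyl of 1-phenylethyl would do here remains open. So does the effect of a fluorine on its phenyl ring.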